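Phenoxy to trifluoromethoxy on compound 1

This account rests on a few compounds, and the source may have more. Where it says the series, first, only, none or still open, it means among the compounds named here.

In a functional assay on MDA-MB-231 cells (Homo sapiens) for cytotoxicity, read by MTT assay (a higher number here means a weaker inhibitor, a lower number a stronger inhibitor), compound 1 `COc1ccc(-c2cn(-c3ccc(Oc4ccccc4)cc3)nn2)cc1` gives > 100 nM, which is a limit and not a number. Compound 3 `COc1ccc(-c2cn(-c3ccc(Oc4ccccc4)cc3)nn2)cc1O` gives > 10000 nM, which is also a limit. Compound 2 `COc1cc(-c2cn(-c3ccc(Oc4ccccc4)cc3)nn2)ccc1O` stands at "not determined" (no result reported). Compound 4 `COc1ccc(-c2cn(-c3ccc(OC(F)(F)F)cc3)nn2)cc1` differs from compound 1 by trifluoromethyl in place of phenyl on an oxygen on an aromatic ring, that is, phenoxy to trifluoromethoxy. Among the compounds with values here, the one measured step, a step that the two limits leave unreadable from compound 1 to compound 3, is a different change, hydroxy in place of hydrogen on an aromatic carbon, and gives no size to carry over. Within the data shown here, the limit > 10000 nM of compound 3 is the only guide, and it leads to the expectation of a weak reading for compound 4. The expected move is a step that the limit leaves unreadable from compound 1 to compound 4, towards weaker inhibition, and this direction is uncertain. For compound 4 the estimated value is 10000 nM, with an expected range of 1500 nM to 60000 nM.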

Compound 4, half-maximal inhibitory concentration: 1000 nM
Compound 4: the middle estimate sits 10-fold (1.00 log units) above what was measured; measured number outside the range, below it.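

Compound 1 stands only at a limit in this assay, and the step from it to compound 4 cannot be read. The compounds shown leave open whether phenoxy or trifluoromethoxy gives the stronger inhibition.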